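The compounds below may be only part of what the source reports. "The series", "measured", "known", "first", "only" and "open" are said of these compounds alone.

Working notes on the series built on the core of compound 1 `CC(=O)O[C@]1(C)/C=C/C(=O)/C(CO)=C\C[C@](C)(CCC=C(C)C)/C=C/[C@H]1OC(=O)C=C(C)C`. In a functional assay on SW480 cells (Homo sapiens) for antiproliferative activity, read by MTT assay, with a stated time of 48 h (a lower number here means a stronger inhibitor, a higher number a weaker inhibitor), compound 1 gives 2010 nM. Compound 3 `CC(C)=CCC[C@]1(C)/C=C/[C@@H](OC(=O)C=C(C)C)[C@](C)(O)CCC(=O)/C(CO)=C\C1` reaches only a limit in this assay, > 40000 nM. Compound 2 `CC(C)=CCC[C@]1(C)/C=C/[C@@H](OC(=O)C=C(C)C)[C@](C)(O)/C=C/C(=O)/C(C(=O)O)=C\C1` likewise yields only a limit, > 10000 nM. Among the three values shown, compound 2 stands at the limit of > 10000 nM in this assay, at which 1 of the 3 values shown sits, with compound 1 the sole entry carrying a number.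

Compound 4 `CCN(CC)C(=O)/C1=C/C[C@](C)(CCC=C(C)C)/C=C/[C@@H](OC(=O)C=C(C)C)[C@](C)(O)/C=C/C1=O` is compound 2 with diethylamino in place of hydroxy on a carbonyl carbon. Among the measured compounds shown here, no measured pair differs at this place, so the step is untested. A gain beyond the scatter is expected, since compound 1 gives 2010 nM and a number rather than a limit seems reachable. The expected step is an at least 1.6-fold lower number from compound 2 to compound 4 (0.22 log units; that floor lies within the scatter). For compound 4 the estimate is 6000 nM, with a range of 1500 nM to 30000 nM.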

Compound 4, half-maximal inhibitory concentration: 11700 nM
Compound 4: middle estimate off by 2.0-fold (0.29 log units), on the low side; the range from low to high includes it.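

Among the compounds shown here, compound 2 gives only a limit of > 10000 nM and no step to compound 4 can be read from it. The compounds shown leave open how large the change is with diethylamino in place of hydroxy on a carbonyl carbon.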